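Carboxy in place of dihydroxybenzyl: working notes

This account rests on a few compounds, and the source may have more. Where it says the series, first, only, none or still open, it means among the compounds named here.

Among the measured compounds shown here, in a functional assay on P388 cells (Mus musculus) for cytotoxicity (on this read-out higher numbers stand for weaker inhibition and lower numbers for stronger inhibition), compound 3 `Cc1cc(-c2c(F)cc3c(=O)c(Cc4cccc(O)c4O)cn(C4CC4)c3c2F)cc(C)n1` gives 880 nM, the lowest number of the three so far. Compound 1 `COc1cccc(Cc2cn(C3CC3)c3c(F)c(-c4cc(C)nc(C)c4)c(F)cc3c2=O)c1` gives 20000 nM and compound 2 `COc1ccc(Cc2cn(C3CC3)c3c(F)c(-c4cc(C)nc(C)c4)c(F)cc3c2=O)cc1` gives 21000 nM; a 1.1-fold higher number from compound 1 to compound 2 (0.02 log units; within the scatter) lies within the scatter. Compound 4 `Cc1cc(-c2c(F)cc3c(=O)c(C(=O)O)cn(C4CC4)c3c2F)cc(C)n1` carries carboxy in place of the 2,3-dihydroxybenzyl of compound 3 (carboxy in place of 2,3-dihydroxybenzyl on an aromatic carbon).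

Two steps at this same place bear on it: a 23-fold lower number from compound 1 to compound 3 (1.36 log units; beyond the scatter) and a 24-fold lower number from compound 2 to compound 3 (1.38 log units; beyond the scatter), both large. For the measured compounds named here, no measured compound carries carboxy, so they only indicate that leaving 2,3-dihydroxybenzyl may raise the number in this assay. A smaller rise than those steps is expected, with wide uncertainty. The expected step is a 4.5-fold higher number from compound 3 to compound 4 (0.66 log units; beyond the scatter). For compound 4 the estimate is 4000 nM, range 900 nM to 20000 nM.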

Compound 4, half-maximal inhibitory concentration: 29000 nM
The estimate for compound 4 lay 7.3-fold (0.86 log units) below the measured number; measured number outside the range, above it.
By their numbers in this assay, from the lowest: compound 3; then compounds 1, 2 and 4 (each within the scatter of the next).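

In this assay, a 33-fold higher number from compound 3 to compound 4 (1.52 log units; beyond the scatter), whereas a 1.4-fold higher number from compound 2 to compound 4 (0.14 log units; within the scatter) and a 1.5-fold higher number from compound 1 to compound 4 (0.16 log units; within the scatter) stay within the scatter. A benzyl ring alone therefore does not set compounds 1 and 2 apart from compound 4, which has no ring at this position; among these four compounds, only the 2,3-dihydroxybenzyl of compound 3 stands apart. Nothing measured here gives a reason for that gap.

What a 3-hydroxybenzyl or a 3,4-dihydroxybenzyl group would give here remains open, so the compounds shown do not tell whether one hydroxy group would be enough or whether the 2,3-dihydroxy pattern is needed.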